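The source may report more compounds than this note shows. Statements on the series, on what has been measured and on what is new or still open speak of the compounds shown alone.

Three compounds of this study share one core and differ only in the group attached through the dithiocarbamate nitrogen. Compound 1, `Nc1ccccc1NC(=O)c1ccc(CSC(=S)N2CCN(c3ccc(F)cc3)CC2)cc1`, carries a piperazine bearing a 4-fluorophenyl; in a functional assay on A-375 cells (Homo sapiens) for antiproliferative activity, read by CCK-8 assay, with a stated time of 72 h, tested at 2 uM (on this read-out lower numbers stand for a weaker effect and higher numbers for a stronger effect at the one concentration tested), compound 1 gives 20.9%. Compound 2, `CCN(Cc1ccncc1)C(=S)SCc1ccc(C(=O)Nc2ccccc2N)cc1`, has an acyclic amine with an ethyl and a pyridinylmethyl; in this assay compound 2 gives 67.2%. Compound 3, `Nc1ccccc1NC(=O)c1ccc(CSC(=S)N(Cc2ccccc2)Cc2ccccc2)cc1`, has two benzyl groups; in this assay compound 3 gives 10.9%. Among these three numbers compound 1 stands second highest: its nearest neighbour is compound 3, whose number lies within the usual scatter of it, while compound 2 lies well beyond the scatter above it.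

Compound 4, `Nc1ccccc1NC(=O)c1ccc(CSC(=S)N2CCN(Cc3cccnc3)CC2)cc1`, has not yet been measured. It differs from compound 1 in one place: (pyridin-3-yl)methyl in place of 4-fluorophenyl on an amine nitrogen in a ring. For the measured compounds named here, no step between two measured compounds matches this change, so the expectation rests on the wider picture. Going by the values given here, compound 2, the only pyridinylmethyl-bearing compound, gives 67.2%, and that hints at a small rise, though compound 2 also lacks the ring amine of compound 1. For compound 4 in this assay a value of 30% is expected, within 10% to 55%. The step this expectation means, a number 9.1 percentage points higher from compound 1 to compound 4 (within the scatter), is estimated to be upward but probably no larger than the scatter.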

Compound 4, a percentage reported as inhibition, at one concentration (the size of the read-out at that concentration, not a potency): 31.5%
For compound 4 the middle estimate is 1.5 percentage points below the measured one; the range from low to high includes it.
By their numbers in this assay, from the lowest: compounds 3 and 1 (each within the scatter of the next); then compound 4; then compound 2.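

In this assay, the only single-place step shown, (pyridin-3-yl)methyl in place of 4-fluorophenyl on an amine nitrogen in a ring, gives a number 10.6 percentage points higher from compound 1 to compound 4 (beyond the scatter) and goes beyond the scatter. It shows that the number responds to the group at this position while the rest of compound 1 stays unchanged. The two groups have the same count of heavy atoms, but the entering one has a ring nitrogen and a hydrogen-bond acceptor, and the fluorine has left; nothing given here explains the step.

This single change alters both the aromatic ring and its link to the ring nitrogen, so the compounds shown do not separate those two parts. From the compounds shown here alone, it remains open whether a benzyl group or a directly attached pyridin-3-yl at that nitrogen would fall nearer compound 1 or compound 4.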